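The source may hold more compounds than are shown below. What is called first, only, known or untested is meant among the compounds shown, and "the series" means these compounds.

Measured in a functional assay on A549 cells (Homo sapiens) for cytotoxicity, read by MTT assay, with a stated time of 72 h; on this read-out higher numbers stand for weaker inhibition and lower numbers for stronger inhibition:
- compound 1 `CN(C)CCn1cnnc1-c1cc(Oc2ccc(NC(=O)N/N=C/c3ccc(F)cc3Cl)cc2F)ccn1`: 1120 nM
- compound 2 `CN(C)CCn1cnnc1-c1cc(Oc2ccc(NC(=O)N/N=C/c3ccc(O)c(O)c3)cc2F)ccn1`: > 100000 nM, a limit of the assay, not a number
- compound 3 `Cc1cc(/C=N/NC(=O)Nc2ccc(Oc3ccnc(-c4nncn4CCN(C)C)c3)c(F)c2)cc(C)c1O`: 1640 nM

Compound 2 stands apart from the other two: only a limit is known for it, the one recorded as the limit of > 100000 nM in this assay, at which 1 of the 3 values shown sits, so its true number is not fixed. The two compounds with numbers sit close together, and the step of a 1.5-fold higher number from compound 1 to compound 3 (0.17 log units; within the scatter) shows that exchanging one aryl group for the other on the carbon with a double bond to nitrogen changes little. Against that, the steps of an at least 89-fold higher number from compound 1 to compound 2 (1.95 log units; beyond the scatter) and an at least 60-fold lower number from compound 2 to compound 3 (1.78 log units; beyond the scatter) are both large, so within this small set the 3,4-dihydroxyphenyl compound is the odd one out.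

Compound 4 `COc1ccc(/C=N/NC(=O)Nc2ccc(Oc3ccnc(-c4nncn4CCN(C)C)c3)c(F)c2)c(OC)c1OC` carries the change (2,3,4-trimethoxyphenyl in place of 3,4-dihydroxyphenyl on a carbon with a double bond to nitrogen). The group entering has no hydrogen-bond donors, like the groups on compound 1 and compound 3, which both gave numbers. Going by the values given here, the steps that bear on this change, an at least 60-fold lower number from compound 2 to compound 3 (1.78 log units; beyond the scatter) and an at least 89-fold higher number from compound 1 to compound 2 (1.95 log units; beyond the scatter), were large, and a step of similar size and direction is expected here, returning compound 4 to a measurable number in this assay. The expected step is an at least 40-fold lower number from compound 2 to compound 4 (1.60 log units; beyond the scatter). Compound 4 is estimated at 2500 nM, within 600 nM to 15000 nM.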

Compound 4, half-maximal inhibitory concentration: 6680 nM
For compound 4 the middle estimate is 2.7-fold (0.43 log units) below the measured one, and the stated range covers the measured number.
By their numbers in this assay, from the lowest: compounds 1 and 3 (each within the scatter of the next); then compound 4. At a limit, above all of these: compound 2.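

In this assay, the 2,3,4-trimethoxyphenyl group on the carbon with a double bond to nitrogen restores a measurable number where 3,4-dihydroxyphenyl gave none, an at least 14-fold lower number from compound 2 to compound 4 (1.17 log units; beyond the scatter). On these data alone, the size of that step stays open, since compound 2 has a limit and not a number: the limit of > 100000 nM in this assay, at which 1 of the 4 values shown sits. The earlier measured compounds lay within the scatter of each other, but this position now also separates compounds with real numbers, with a 4.1-fold higher number from compound 3 to compound 4 (0.61 log units; beyond the scatter) and a 6.0-fold higher number from compound 1 to compound 4 (0.78 log units; beyond the scatter), so a measurable number here does not settle the choice of aryl group.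

Compound 3 keeps a hydroxy group and still gives a number, so the shown compounds do not tell whether the loss in compound 2 goes with the two hydroxy groups together or with their placement on the ring. A 3,4-dimethoxyphenyl or a 4-aminophenyl group on the same carbon would bear on this, and a 4-carboxyphenyl group would test a different kind of substituent at this position.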